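The source may report more compounds than this note shows. Statements on the series, on what has been measured and on what is new or still open speak of the compounds shown alone.

Compound 3 `CC(=O)Oc1ccc2c(c1)C(n1ccccc1=O)=CC(C)(C)O2` stands lowest of the three measured entries: in a functional assay (aorta) with Rattus norvegicus as the target (a lower number here means a less potent compound, a higher number a more potent compound, by a factor of ten per unit of this negative logarithm), compound 3 gives 5.6. Compound 1 `CC1(C)C=C(n2ccccc2=O)c2cc(C(=O)c3ccco3)ccc2O1` gives 6.49 and compound 2 `CC1(C)C=C(n2ccccc2=O)c2cc(C(=O)c3ccccc3F)ccc2O1` gives 7.08, and the steps of a number 0.89 log units lower from compound 1 to compound 3 (beyond the scatter) and a number 1.48 log units lower from compound 2 to compound 3 (beyond the scatter) both place compound 3 clearly at the bottom.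

Compound 4 `CC1(C)C=C(n2ccccc2=O)c2cc(C#N)ccc2O1` differs from compound 3 by cyano in place of acetoxy on an aromatic carbon. Going by the values given here, no measured step involves a cyano group; the only steps at the same aromatic carbon exchange an aryl carbonyl for acetoxy, and both lowered the number. They offer no direct guide to cyano, so the direction is uncertain, though a return toward the level of compound 1 seems at least as likely as a further fall. Compound 4 is expected to give 6.2, with a range from 5.3 to 7.1. This estimate corresponds to a step of a number 0.60 log units higher from compound 3 to compound 4 (beyond the scatter).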

Compound 4, logarithm of the reciprocal of the active concentration, log(1/C): 7.67
The estimate for compound 4 lay 1.47 log units below the measured number; measured number outside the range, above it.
By their numbers in this assay, from the lowest: compound 3; then compound 1; then compound 2; then compound 4.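

At this aromatic carbon, an aryl carbonyl is not required for a high number in this assay: cyano gives a number 0.59 log units higher from compound 2 to compound 4 (beyond the scatter) and a number 1.18 log units higher from compound 1 to compound 4 (beyond the scatter). The change from acetoxy gives a number 2.07 log units higher from compound 3 to compound 4 (beyond the scatter), and heavy-atom count does not order the series, since cyano has fewer than acetoxy and stands higher, while the larger aryl carbonyl groups also stand above acetoxy. No available measurement accounts for these steps.

From the compounds shown here alone, whether an amine, a carboxylic acid or a trifluoromethyl group at this carbon would match cyano remains open. Whether the cyano gain holds with other changes to the shared core is also unresolved.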